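Growth inhibition series: expectation for compound 4

The source may report more compounds than this note shows. Statements on the series, on what has been measured and on what is new or still open speak of the compounds shown alone.

Three compounds of the series have numbers in a functional assay on COLO 205 cells (Homo sapiens) for inhibition, read by sulforhodamine B assay; a lower number here means a stronger inhibitor of growth, a higher number a weaker inhibitor of growth. Compound 1 `Cc1ccc2[nH]c(-c3ccc(-c4ccc(-c5ccc(N(C)C)cc5)cc4)cc3)nc2c1` gives 9210 nM. Compound 2 `Cc1ccc2[nH]c(-c3ccc(-c4ccc(-c5cccc(Cl)c5)cc4)cc3)nc2c1` gives 2780 nM, and compound 3 `CN(C)c1ccc(-c2ccc(-c3ccc(-c4nc5c(O)cccc5[nH]4)cc3)cc2)cc1` gives 6320 nM. Compound 2 differs from compound 1 by 3-chlorophenyl in place of 4-(dimethylamino)phenyl on an aromatic carbon, a change that brought a 3.3-fold lower number from compound 1 to compound 2 (0.52 log units; beyond the scatter). Compound 3 differs from compound 1 in the core, by 4-hydroxy-1H-benzimidazol-2-yl in place of 5-methyl-1H-benzimidazol-2-yl on an aromatic carbon, a change that brought a 1.5-fold lower number from compound 1 to compound 3 (0.16 log units; within the scatter); compound 3 and compound 1 therefore sit within the scatter of each other in this assay.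

Compound 4 `Oc1cccc2[nH]c(-c3ccc(-c4ccc(-c5cccc(Cl)c5)cc4)cc3)nc12` is not yet measured. It carries the core of compound 3 and takes the change that compound 2 took from compound 1: 3-chlorophenyl in place of 4-(dimethylamino)phenyl on an aromatic carbon. This change appears in two pairs among the compounds shown, and the place is the same word for word in both, so it is the same change. Going by the values given here, the one measured instance, the step from compound 1 to compound 2, is the only ground for what to expect on the core of compound 3. That the core change itself, a 1.5-fold lower number from compound 1 to compound 3 (0.16 log units; within the scatter), stayed within the scatter supports carrying the step over unchanged, so a step of about the same size is expected, a 3.0-fold lower number from compound 3 to compound 4 (0.48 log units; beyond the scatter). Compound 4 is accordingly estimated at 2100 nM, with a range from 900 nM to 5000 nM.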

Compound 4, concentration for 50% growth inhibition: 8600 nM
Compound 4: the middle estimate sits 4.1-fold (0.61 log units) below what was measured, outside the stated range (above it).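

On the core of compound 3, 3-chlorophenyl in place of 4-(dimethylamino)phenyl gave, in this assay, a 1.4-fold higher number from compound 3 to compound 4 (0.13 log units; within the scatter), so the gain seen on the core of compound 1 did not carry over. Set side by side, the two instances of this change do not agree, and in this series the size of the step cannot be taken as independent of the core: the same change on two cores in this assay, a 3.3-fold lower number (0.52 log units; beyond the scatter) from compound 1 to compound 2 and a 1.4-fold higher number (0.13 log units; within the scatter) from compound 3 to compound 4, 4.5-fold (0.65 log units) apart, beyond the scatter of two such steps
This comparison rests on a single pair on each of two cores, so it shows that the step failed to transfer in this one case, but it does not show which feature of the core is responsible, nor how the change would behave on any further core.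

Going by these compounds, it remains open whether the difference between the two steps follows the hydroxyl on the core of compound 3 or the loss of the methyl on the core of compound 1, a question that a core carrying a methoxy group or an amine in place of that hydroxyl could help to separate. On these data alone, it is also open whether other terminal groups, such as a carboxylic acid or a morpholine, would show the same dependence on the core.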